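A few compounds are considered here, and "the series" means these few. Any claim that something is new, unique, unknown or untested is made for them only; others in the source may bear on it.

Compound 1 `CC(C)c1ccc(-c2cc(Cl)cc(C(=O)Nc3nn[nH]n3)n2)cc1`: 68%
Compound 2 `COc1ccc(-c2cccc(C(=O)Nc3nn[nH]n3)n2)cc1`: 36%
Compound 3 `COc1ccc(-c2cc(C)cc(C(=O)Nc3nn[nH]n3)n2)cc1`: 43%

Of the compounds shown here, three built on a shared core have been tested in a functional assay on the whole organism with Rattus norvegicus as the target, at a dose of 3 mg/kg by the oral route; on this read-out lower numbers stand for a weaker effect and higher numbers for a stronger effect at the one dose given. Compound 3 stands second highest of the three numbers. Its nearest neighbour is compound 2, which in this assay gives 36%, a gap that lies within the scatter of repeated measurements. The furthest is compound 1, which gives 68%, a gap that lies beyond the scatter.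

Compound 4 `Cc1cc(C(=O)Nc2nn[nH]n2)nc(-c2ccc(C(C)C)cc2)c1` arises from compound 3 by one change: isopropyl in place of methoxy on an aromatic carbon.

For the measured compounds named here, only one single-point step has been measured, a number 7 percentage points higher from compound 2 to compound 3 (within the scatter), and it concerns methyl in place of hydrogen, so it says nothing about exchanging methoxy for isopropyl. Going by the values given here, no measured pair differs by that exchange alone. Compound 1 does carry the isopropyl group, but it also differs from compound 3 in another place. In this assay compound 3 gives 43%, while compound 1 gives 68%, which can only hint that isopropyl-bearing members may sit higher.

On that thin basis compound 4 is expected to rise, with a step of a number 15 percentage points higher from compound 3 to compound 4 (beyond the scatter), though the uncertainty is wide. The estimate for compound 4 in this assay is 58%, in a range from 38% to 78%.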

Compound 4, a percentage reported as inhibition, in the whole organism at one dose (the size of the read-out at that dose, not a potency): 100%
Compound 4: middle estimate off by 42 percentage points, on the low side; the whole stated range lies below it.
By their numbers in this assay, from the lowest: compounds 2 and 3 (each within the scatter of the next); then compound 1; then compound 4.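

In this assay, the step of a number 57 percentage points higher from compound 3 to compound 4 (beyond the scatter) isolates isopropyl in place of methoxy on an aromatic carbon, para to a large group, and shows that this single exchange can change the effect at the one dose given by a large amount. For the compounds shown here, the second varied place matters as well: with isopropyl present, methyl in place of chloro gives the step of a number 32 percentage points higher from compound 1 to compound 4 (beyond the scatter), whereas the earlier change at that place, methyl in place of hydrogen with methoxy present, gave only the step of a number 7 percentage points higher from compound 2 to compound 3 (within the scatter). Nothing available here explains why either large step occurs.

The compounds shown leave open whether a tert-butyl group or a longer chain such as n-butyl would match isopropyl on that aromatic carbon, and whether an amine there would keep any of the effect. They also leave open how hydrogen or ethyl would compare with methyl in the presence of isopropyl, and a read-out at one dose does not give a potency for any of these compounds.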